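Swapping the carbonyl for a sulfonyl on compound 2

A few compounds are considered here, and "the series" means these few. Any claim that something is new, unique, unknown or untested is made for them only; others in the source may bear on it.

In an assay on Sf9 cells for inhibition of mitogen-activated protein kinase kinase kinase 20 (Homo sapiens), read by ADP-Glo, with a stated time of 30 min (on this read-out higher numbers stand for weaker inhibition and lower numbers for stronger inhibition), compound 1 `COc1n[nH]c2ncc(C#Cc3c(F)ccc(NS(=O)(=O)c4cccc(Cl)c4)c3F)cc12` gives 14.7 nM, while compound 2 `COc1n[nH]c2ncc(-c3cn(-c4c(F)ccc(NC(=O)c5cccc(Cl)c5)c4F)nn3)cc12` gives 54.3 nM, the higher of the two numbers and beyond the scatter apart from compound 1. Compound 3 `COc1n[nH]c2ncc(-c3cn(-c4c(F)ccc(NS(=O)(=O)c5cccc(Br)c5)c4F)nn3)cc12` differs from compound 2 by (3-bromophenyl)sulfonyl in place of (3-chlorophenyl)carbonyl on a nitrogen on an aromatic ring. Among the compounds with values here, no measured pair isolates this single change, and compound 1 and compound 2 differ in more than one place, so their gap cannot be assigned to it. Compound 3 is therefore expected to shift only modestly toward a lower number, with a 1.9-fold lower number from compound 2 to compound 3 (0.29 log units; within the scatter), giving an estimate of 28 nM within a range from 8 nM to 90 nM.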

Compound 3, half-maximal inhibitory concentration: 2.1 nM
Beside the measured number, compound 3's estimate is 13-fold (1.12 log units) above it; the measured number lies below the stated range.
By their numbers in this assay, from the lowest: compound 3; then compound 1; then compound 2.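

Replacing (3-chlorophenyl)carbonyl with (3-bromophenyl)sulfonyl on a nitrogen on an aromatic ring gives a 26-fold lower number from compound 2 to compound 3 (1.41 log units; beyond the scatter) in this assay and shows that the activity responds strongly to the group at this place. The step changes carbonyl to sulfonyl and chlorine to bromine together, so it cannot be divided between them. Nothing given here accounts for the size of the step.

The compounds shown leave open how much each of the two changes contributes alone. They also leave open how a methyl group, an amine or a carboxylic acid in place of the bromine would read.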